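Ethyl on the Ring Carbon: a Step Carried Over

This account rests on a few compounds, and the source may have more. Where it says the series, first, only, none or still open, it means among the compounds named here.

The series opens with compound 1, `O=C1c2ccc(Cl)cc2CN1c1cccnc1`, and its ethyl analogue compound 2, `CCC1c2cc(Cl)ccc2C(=O)N1c1cccnc1`. In an ADME assay on cells for inhibition of cytochrome P450 11B1, mitochondrial (Homo sapiens), read by HTRF (on this read-out lower numbers stand for stronger inhibition and higher numbers for weaker inhibition), compound 1 gives 10700 nM, and compound 2 gives 3340 nM. The two differ in one place, (ethyl in place of hydrogen on a saturated ring carbon), and this change made a step of a 3.2-fold lower number from compound 1 to compound 2 (0.51 log units; beyond the scatter).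

Compound 3, `CC(=O)N[C@@H]1CCCc2c1cncc2N1Cc2cc(Cl)ccc2C1=O`, rests on a different core; the difference between the two cores is not broken down here. In this assay compound 3 gives 2330 nM, which lies within the scatter of the value of compound 2 and beyond it against compound 1.

Compound 4, `CC[C@H]1c2cc(Cl)ccc2C(=O)N1c1cncc2c1CCC[C@H]2NC(C)=O`, has not yet been measured. It differs from compound 3 by ethyl in place of hydrogen on a saturated ring carbon. Around that place the surroundings are not described in the same words: in compound 1 the change sits next to the ring atom that bears a pyridin-3-yl group (6 heavy atoms), whereas in compound 3 it sits next to the ring atom that bears a large group. It is therefore the same kind of change, not the same one, and it occurs twice among these compounds.

For compound 4 in this assay a step of a 3.1-fold lower number from compound 3 to compound 4 (0.49 log units; beyond the scatter) is expected, resting on the step seen from compound 1 to compound 2, which rested on a 3.2-fold lower number from compound 1 to compound 2 (0.51 log units; beyond the scatter). Compound 4 is thus estimated at 750 nM, with a range from 350 nM to 1600 nM.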

Compound 4, half-maximal inhibitory concentration: 3630 nM
For compound 4 the middle estimate is 4.8-fold (0.68 log units) below the measured one; the measured number lies above the stated range.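

In this assay, among these compounds, ethyl in place of hydrogen on a saturated ring carbon gave a 1.6-fold higher number from compound 3 to compound 4 (0.19 log units; within the scatter), so on the core of compound 3 the change produced no step that stands clear of repeat measurement. Set beside the earlier step, the result shows that the gain seen on the core of compound 1 did not carry over to the core of compound 3: the same change on two cores in this assay, a 3.2-fold lower number (0.51 log units; beyond the scatter) from compound 1 to compound 2 and a 1.6-fold higher number (0.19 log units; within the scatter) from compound 3 to compound 4, 5.0-fold (0.70 log units) apart, beyond the scatter of two such steps. Within these four compounds, then, the size of the step differs with the core, but two pairs do not show which of the differences between the cores matters, and they say nothing about any other core or assay.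

From the compounds shown here alone, it remains open whether a methyl or a longer chain such as propyl on the same ring carbon would separate the two cores as ethyl does, or whether an amine there would behave differently again. Going by these compounds, compound 4 is drawn with one defined arrangement at the carbon bearing the ethyl, whereas compound 2 is drawn with none, so how the opposite arrangement would read on the core of compound 3 also stays open.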